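Chloro to fluoro on the benzyl arm of compound 1

The source may report more compounds than this note shows. Statements on the series, on what has been measured and on what is new or still open speak of the compounds shown alone.

Measured compounds:
- compound 1, `COc1cc(F)c(CN2C(=O)N(c3ccc(OC)c(OC)c3)S(=O)(=O)c3ccccc32)c(Cl)c1`: 0.398 nM
- compound 2, `COc1cc(N2C(=O)N(Cc3c(F)cc(F)cc3Cl)c3ccccc3S2(=O)=O)cnc1OC`: 39.8 nM
- compound 3, `COc1cc(N2C(=O)N(Cc3c(F)cc(F)cc3F)c3ccccc3S2(=O)=O)ccn1`: 398 nM

In an assay on isolated protein for displacement of a labelled ligand from Orexin/Hypocretin receptor type 1 (Homo sapiens), with a stated time of 90 min (on this read-out higher numbers stand for weaker inhibition and lower numbers for stronger inhibition), compound 1 gives 0.398 nM, the lowest of the three numbers. Compound 2 gives 39.8 nM and compound 3 gives 398 nM; both gaps to compound 1 lie beyond the scatter, so compound 1 is the strongest binder of the set. Compound 2 and compound 3 differ from compound 1 at more than one place, so their values say nothing on their own about any single change.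

Compound 4, `COc1cc(F)c(CN2C(=O)N(c3ccc(OC)c(OC)c3)S(=O)(=O)c3ccccc32)c(F)c1`, has not been measured. It differs from compound 1 in one place: fluoro in place of chloro on an aromatic carbon. The change is small and the halogen keeps its position on the 2,6-difluoro-4-methoxybenzyl group. Among the compounds with values here, no measured pair isolates this change, so the step is an expectation only: the step from compound 1 to compound 4 in this assay is expected to be a 2.5-fold higher number from compound 1 to compound 4 (0.40 log units; beyond the scatter), a modest weakening that may not exceed the scatter. Compound 4 is therefore expected to give about 1 nM, within 0.3 nM to 4 nM.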

Compound 4, inhibition constant: 2 nM
Estimate against measurement, compound 4: 2.0-fold (0.30 log units) below; the measured number falls inside the stated range.
By their numbers in this assay, from the lowest: compound 1; then compound 4; then compound 2; then compound 3.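

In this assay, within the data shown here, fluoro in place of chloro on the benzyl arm gives a 5.0-fold higher number from compound 1 to compound 4 (0.70 log units; beyond the scatter) and is the first comparison that isolates a single change. The chlorine therefore counts at this position: the 2-chloro-6-fluoro-4-methoxybenzyl group holds the lower number, although the step is modest and compound 4 still reads 2 nM with the 2,6-difluoro-4-methoxybenzyl group in place. No measurement at hand bears on why the step has this size.

The compounds shown leave open how bromo, methyl, methoxy or a plain hydrogen would read at this same position, and so whether the number follows any trend across substituents or reflects only this one pair of halogens. As far as these compounds go, it also remains open whether the same exchange gives a step of similar size when the other aryl group of compound 1 is replaced by that of compound 2 or compound 3, as neither of those compounds forms a single-change pair with compound 1 or compound 4.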